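Replacing the sulfur substituent of compound 1

The source may hold more compounds than are shown below. What is called first, only, known or untested is meant among the compounds shown, and "the series" means these compounds.

In a functional assay on SMMC-7721 cells (Homo sapiens) for inhibition, read by CCK-8 assay, with a stated time of 72 h, tested at 2 uM (a lower number here means less inhibition of growth, a higher number more inhibition of growth at the concentration tested), compound 1 `COc1ccc(SCc2ccc(/C=C/C(=O)Nc3ccccc3N)cc2)cc1OC` gives 14.3% and stands lowest of the two numbers in hand. The nearest number comes from compound 2 `CCc1ccc(SCc2ccc(C(=O)Nc3ccccc3N)cc2)cc1` at 25.7% and lies higher, beyond the usual scatter. The two differ in more than one place, so their gap does not measure any single change.

The next structure is compound 3 `Nc1ccccc1NC(=O)/C=C/c1ccc(CSc2cccc3ccccc23)cc1`, with naphthalen-1-yl in place of 3,4-dimethoxyphenyl on a sulfur and the rest of the core of compound 1 unchanged. For the measured compounds named here, the counted difference reads naphthalen-1-yl in place of 3,4-dimethoxyphenyl on a sulfur and no measured pair shows what such a swap does in this assay.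

The expectation therefore rests on thin ground. The low number of compound 1 at 14.3% leaves more room upward than downward. A small rise is expected, with the estimated step of a number 7.7 percentage points higher from compound 1 to compound 3 (within the scatter) not clearly beyond the scatter. Compound 3 is estimated at 22% within an expected range of 8% to 42%.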

Compound 3, percent growth inhibition at one concentration: 3.7%
Compound 3: the middle estimate sits 18.3 percentage points above what was measured; the whole stated range lies above it.
By their numbers in this assay, from the lowest: compound 3; then compound 1; then compound 2.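

In this assay, for the compounds shown here, the substituent on a sulfur whose other neighbour is a saturated chain carbon proves able to move the read-out: naphthalen-1-yl in place of 3,4-dimethoxyphenyl gives a number 10.6 percentage points lower from compound 1 to compound 3 (beyond the scatter), a modest change and the first single-place step. The two groups have the same count of 10 heavy atoms, so heavy-atom count alone does not set the reading here, while the entering group has 2 six-membered aromatic rings and 0 hydrogen-bond acceptors, against one such ring and 2 acceptors in the group that leaves. Nothing at hand bears on why the number falls, and this one pair does not separate the change in ring count from the loss of the two oxygen atoms.

Still open, as far as these compounds go, is where a plain phenyl, with neither the second ring nor the methoxy groups, or a pyridin-3-yl would fall at this sulfur, and such a group could begin to separate those two changes. Also open, from the compounds shown here alone, is whether the same swap gives a step of similar direction and size on the core of compound 2.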